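Aryl ester in place of the amide side chain

The source may hold more compounds than are shown below. What is called first, only, known or untested is meant among the compounds shown, and "the series" means these compounds.

Compound 1 `CCn1c(C(=O)NCCN(C)C)ccc1C(CC)(CC)c1ccc(OCC(O)C(C)(C)C)c(C)c1` is the reference for this step. In a functional assay on HepG2 cells (Homo sapiens), read by MTT assay, with a stated time of 48 h (a higher number here means a weaker inhibitor, a lower number a stronger inhibitor), compound 1 gives 870 nM; on the three numbers shown it stands second highest, with compound 3 `CC[C@@H](C)[C@H](NC(=O)c1ccc(C(CC)(CC)c2ccc(OCC(=O)C(C)(C)C)c(C)c2)n1CC)C(=O)O` giving 247 nM and compound 2 `CCn1c(C(=O)NCC(OC)OC)ccc1C(CC)(CC)c1ccc(OCC(O)C(C)(C)C)c(C)c1` giving 23200 nM.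

The change to compound 4 `CCn1c(C(=O)Oc2ccc(CCO)cc2)ccc1C(CC)(CC)c1ccc(OCC(O)C(C)(C)C)c(C)c1` is a group of 10 heavy atoms (8 carbon, 2 oxygen; one six-membered aromatic ring of carbon only) in place of a group of 6 heavy atoms (4 carbon, 2 nitrogen; no ring), on a carbonyl carbon. Going by the values given here, the only measured step that touches the same side chain is a 27-fold higher number from compound 1 to compound 2 (1.43 log units; beyond the scatter), where the amide itself stayed and only the terminal group of the chain was exchanged. Compound 4 goes further: the amide nitrogen and its chain leave altogether, and an ester to a ring bearing a hydroxyethyl group enters on the carbonyl carbon. Compound 3 shows that a different side chain on the same carbonyl can also give a lower number, so the direction is not fixed by the data. Given that the one related step was large and upward, a higher number is expected for compound 4, with wide uncertainty: a 4.0-fold higher number from compound 1 to compound 4 (0.60 log units; beyond the scatter). Compound 4 is therefore estimated at 3500 nM, within 600 nM to 20000 nM.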

Compound 4, half-maximal inhibitory concentration: > 50000 nM
Compound 4: no number, only a limit; the forecaster's own chance of this, stated with the estimate: 10%; middle value at least 14-fold (1.15 log units) from the limit.
By their numbers in this assay, from the lowest: compound 3; then compound 1; then compound 2. At a limit, above all of these: compound 4.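

In this assay compound 4 gives > 50000 nM, which is a limit and not a number: the limit of > 50000 nM in this assay, at which 1 of the 4 values shown sits. On the carbonyl carbon, the group of compound 4 in place of (2-(dimethylamino)ethyl)amino gives an at least 57-fold higher number from compound 1 to compound 4 (1.75 log units; beyond the scatter), so a change at this position can move the read-out upward by a large step even when the rest of the molecule stays the same. The step of an at least 2.1-fold higher number from compound 2 to compound 4 (0.33 log units; beyond the scatter) adds that the aryl ester also stands above the amide with the dimethoxymethyl terminus, which was the highest number until now.

The amide nitrogen leaves as the ring enters, so the compounds shown do not separate these two changes. An amide carrying the same hydroxyethyl-bearing ring, or an ester carrying the 2-(dimethylamino)ethyl chain, would tell them apart.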